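A Smaller Substituent on a Shared Nucleoside Core

This account rests on a few compounds, and the source may have more. Where it says the series, first, only, none or still open, it means among the compounds named here.

Three nucleoside analogues share one core. Compound 1 `O=c1[nH]cnc2c1c(-c1cccs1)cn2[C@@H]1O[C@H](CO)[C@@H](O)[C@H]1O` was tested in a functional assay on K562 cells (Homo sapiens), read by MTT assay, with a stated time of 72 h (on this read-out higher numbers stand for weaker inhibition and lower numbers for stronger inhibition), and for compound 1 the read-out gives only the limit > 20000 nM. Compound 2 `Nc1nc2c(c(-c3ccco3)cn2[C@@H]2O[C@H](CO)[C@@H](O)[C@H]2O)c(=O)[nH]1` likewise reaches only the limit > 20000 nM in this assay. Compound 3 `Cc1nc(N)c2c(-c3cccs3)cn([C@@H]3O[C@H](CO)[C@@H](O)[C@H]3O)c2n1` stands at the same place: in this assay compound 3 returns the limit > 20000 nM, so no number is known for it. All three values sit at the limit of > 20000 nM in this assay, at which 3 of the 3 values shown sit. Compound 4 `C#Cc1cn([C@@H]2O[C@H](CO)[C@@H](O)[C@H]2O)c2nc(C)nc(N)c12` differs from compound 3 by ethynyl in place of thiophen-2-yl on an aromatic carbon. For the measured compounds named here, no measured step between these compounds yields a number, so the expectation rests on the limits alone. The step is expected to be none beyond the scatter, a step that the limit leaves unreadable from compound 3 to compound 4. Compound 4 is estimated at 25000 nM, between 6000 nM and 100000 nM, most likely reported again as a limit.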

Compound 4, half-maximal inhibitory concentration: 3290 nM
The estimate for compound 4 lay 7.6-fold (0.88 log units) above the measured number, outside the stated range (below it).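

At this aromatic carbon, ethynyl in place of thiophen-2-yl gives an at least 6.0-fold lower number from compound 3 to compound 4 (0.78 log units; beyond the scatter) in this assay. The earlier compounds shown here gave no number, so this position is now seen to respond to a change of group, and here the smaller group without a ring gives a readable value. Compound 4 alone leaves the limit, which holds the others: the limit of > 20000 nM in this assay, at which 3 of the 4 values shown sit.

As far as these compounds go, the true size of the step stays open, since it starts from a limit. Also open, from the compounds shown here alone, are whether an amine or a propyl chain at this carbon would give a number, and whether ethynyl would do the same on the core of compound 1.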